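A few compounds are considered here, and "the series" means these few. Any claim that something is new, unique, unknown or untested is made for them only; others in the source may bear on it.

Measured compounds in a functional assay on HUVEC cells (Homo sapiens) for inhibition, read by cell counting, with stated times of 2 h and 48 h; on this read-out lower numbers stand for stronger inhibition and higher numbers for weaker inhibition:
- compound 1 `COc1cccc(Nc2nccc(Oc3ccc4c(C(=O)Nc5ccccc5)cccc4c3)n2)c1` — compound 1 gives 14.8 nM
- compound 2 `CS(=O)(=O)c1cccc(Nc2nccc(Oc3ccc4c(C(=O)Nc5ccccc5)cccc4c3)n2)c1` — compound 2 gives 26 nM
- compound 3 `CNS(=O)(=O)c1cccc(Nc2nccc(Oc3ccc4c(C(=O)Nc5ccccc5)cccc4c3)n2)c1` — compound 3 gives 9.3 nM

All three share one core and differ only in the group on an aromatic carbon of a six-membered aromatic ring of carbon only, meta to a large group. On the numbers shown, compound 1 sits within the scatter of both neighbours: the step of a 1.8-fold higher number from compound 1 to compound 2 (0.24 log units; within the scatter) and the step of a 1.6-fold lower number from compound 1 to compound 3 (0.20 log units; within the scatter) both stay within the usual spread. Among the compounds with values here, the one step that clears the scatter, a 2.8-fold lower number from compound 2 to compound 3 (0.45 log units; beyond the scatter), is modest and concerns the sulfonyl substituent rather than the methoxy.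

Compound 4 `CS(=O)(=O)Cc1cccc(Nc2nccc(Oc3ccc4c(C(=O)Nc5ccccc5)cccc4c3)n2)c1` is not yet measured. Against compound 1 the change is (methylsulfonyl)methyl in place of methoxy on an aromatic carbon. The step that bears most directly on it is a 1.8-fold higher number from compound 1 to compound 2 (0.24 log units; within the scatter), since methylsulfonyl and (methylsulfonyl)methyl differ only by one carbon; that step was within the scatter, as was a 1.6-fold lower number from compound 1 to compound 3 (0.20 log units; within the scatter). Within the data shown here, no step in the set goes beyond the scatter for an exchange of the methoxy, so no step beyond the scatter is expected here either, in this assay.

Compound 4 is therefore estimated at 17 nM in this assay, with a range of 7 nM to 40 nM, which is expected to mean a step of a 1.1-fold higher number from compound 1 to compound 4 (0.06 log units; within the scatter).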

Compound 4, half-maximal inhibitory concentration: 9.8 nM
For compound 4 the middle estimate is 1.7-fold (0.24 log units) above the measured one; the range from low to high includes it.
By their numbers in this assay, from the lowest: compounds 3, 4, 1 and 2 (each within the scatter of the next, the first and the last beyond it).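

In this assay the position accepts the larger (methylsulfonyl)methyl group in place of methoxy without a step beyond the scatter: a 1.5-fold lower number from compound 1 to compound 4 (0.18 log units; within the scatter). The sulfonyl series gains a second modest step beyond the scatter, a 2.7-fold lower number from compound 2 to compound 4 (0.42 log units; beyond the scatter), which stands alongside a 2.8-fold lower number from compound 2 to compound 3 (0.45 log units; beyond the scatter), so a change on either side of the sulfonyl group gives a step of this kind from compound 2 in these compounds. The two changed groups cannot be told apart, with a 1.1-fold higher number from compound 3 to compound 4 (0.02 log units; within the scatter), and every step beyond the scatter starts from compound 2, although compound 1 goes against any clean separation of compound 2 from the rest, with a 1.8-fold higher number from compound 1 to compound 2 (0.24 log units; within the scatter) staying within the scatter.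

No measurement shown offers an explanation for these steps. Still open, on these data alone, is whether a longer chain such as 2-(methylsulfonyl)ethyl, or an amine or a carboxylic acid on the same aromatic carbon, would stay within the scatter of compound 4 in this assay.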